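A Methoxyphenyl Swap on the Shared Core

A few compounds are considered here, and "the series" means these few. Any claim that something is new, unique, unknown or untested is made for them only; others in the source may bear on it.

Measured compounds:
compound 1, `O=C(CN1CCN(c2ccccc2F)CC1)Nc1nc2ccccc2[nH]1`: 56.6%
compound 2, `COc1ccc(N2CCN(CC(=O)Nc3nc4ccccc4[nH]3)CC2)cc1`: 53.2%

In a functional assay, read by spectrophotometry, with a stated time of 30 min, tested at 150 ug/mL (a lower number here means a weaker effect, a higher number a stronger effect of the compound at the concentration tested), compound 1 gives 56.6% and compound 2 gives 53.2%. Among the measured compounds shown here, these are the only two numbers so far, and they lie within the usual scatter of each other, so neither compound can be called stronger or weaker than the other. For the measured compounds named here, the one measured step is a number 3.4 percentage points lower from compound 1 to compound 2 (within the scatter), which came with 4-methoxyphenyl in place of 2-fluorophenyl on an amine nitrogen in a ring.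

Compound 3, `COc1ccccc1N1CCN(CC(=O)Nc2nc3ccccc3[nH]2)CC1`, differs from compound 2 as follows: 2-methoxyphenyl in place of 4-methoxyphenyl on an amine nitrogen in a ring. No measured step covers this particular exchange; the only step shown concerns a different pair of groups at the same place, and it stayed within the scatter. On that basis nothing beyond the scatter is expected here either. The step of a number 0.2 percentage points lower from compound 2 to compound 3 (within the scatter) is therefore estimated to be no larger than the usual scatter. Compound 3 is expected to give about 53% in this assay, with a range from 40% to 66%.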

Compound 3, a percentage reported as activity, at one concentration (the size of the read-out at that concentration, not a potency): 55.2%
Compound 3: the middle estimate sits 2.2 percentage points below what was measured, within the range that was stated.
By their numbers in this assay, from the lowest: compounds 2, 3 and 1 (each within the scatter of the next).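

In this assay, moving the methoxy group, so that 2-methoxyphenyl stands in place of 4-methoxyphenyl on the same amine nitrogen in a ring, comes with a number 2 percentage points higher from compound 2 to compound 3 (within the scatter) and so makes no difference that can be read. The new compound also gives a second comparison with a different group at the same spot: methoxy in place of fluoro on an aromatic carbon comes with a number 1.4 percentage points lower from compound 1 to compound 3 (within the scatter), which again cannot be told apart from repeat-to-repeat variation, so for these three compounds neither the kind of group tried nor where the methoxy sits separates them. No supporting measurement is available to say what lies behind this flat result.

On these data alone, what stays open is whether a group of another kind on this phenyl ring, such as a carboxylic acid or an amine, or a methyl in place of the whole phenyl ring, would move the number beyond the scatter. As far as these compounds go, each compound also has a reading at one concentration only, so how these compounds compare in potency remains unknown.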